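The source may hold more compounds than are shown below. What is called first, only, known or untested is meant among the compounds shown, and "the series" means these compounds.

Compound 3 `COc1ccc(Nc2nc(-c3ccccc3)c(Cc3c(O)ccc4ccccc34)c(=O)[nH]2)cc1` gives 18500 nM in a functional assay on RT-112 cells (Homo sapiens) for antiproliferative activity, read by MTT assay, with a stated time of 3 h; a higher number here means a weaker inhibitor, a lower number a stronger inhibitor. Among the three measured compounds its number is the second highest: compound 2 `CCN(CC)c1nc(-c2ccccc2)c(Cc2c(O)ccc3ccccc23)c(=O)[nH]1` gives 32200 nM, and the gap a 1.7-fold lower number from compound 2 to compound 3 (0.24 log units; within the scatter) lies within the scatter, while compound 1 `CCCCNc1nc(-c2ccccc2)c(Cc2c(O)ccc3ccccc23)c(=O)[nH]1` gives 1900 nM, and the step of a 9.7-fold higher number from compound 1 to compound 3 (0.99 log units; beyond the scatter) is beyond it. The step of a 17-fold higher number from compound 1 to compound 2 (1.23 log units; beyond the scatter) is the largest of the three.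

Compound 4 `O=c1[nH]c(Nc2ccc(O)cc2)nc(-c2ccccc2)c1Cc1c(O)ccc2ccccc12` differs from compound 3 in one place: hydrogen in place of methyl on an oxygen on an aromatic ring. Going by the values given here, no measured step touches the methoxy group itself; the two steps that start from compound 1, to compound 2 and to compound 3, both change the substituent on the amine nitrogen and say nothing about swapping a methyl on the oxygen of that phenyl ring for a hydrogen. The small group that leaves carries no ring and no hydrogen-bond donor or acceptor, and the difference is a single carbon. With nothing in the measured set to point either way, compound 4 is expected to stay close to compound 3, giving a step of a 1.2-fold lower number from compound 3 to compound 4 (0.06 log units; within the scatter) that does not clearly exceed the scatter. The estimate for compound 4 in this assay is therefore 16000 nM, with a range from 5000 nM to 50000 nM.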

Compound 4, half-maximal inhibitory concentration: > 300000 nM
Compound 4 ended at the assay's limit (the forecaster's own chance of this, stated with the estimate: 5%); middle value at least 18-fold (1.27 log units) from the limit.
By their numbers in this assay, from the lowest: compound 1; then compounds 3 and 2 (each within the scatter of the next). At a limit, above all of these: compound 4.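

In this assay compound 4 gives > 300000 nM, which is a limit of the assay and not a number: the limit of > 300000 nM in this assay, at which 1 of the 4 values shown sits. Until now every step had changed the group on the amine nitrogen, whereas here only a methyl on an oxygen on an aromatic ring gives way to hydrogen, and this change of a single carbon still produces an at least 16-fold higher number from compound 3 to compound 4 (1.20 log units; beyond the scatter), showing that the activity in this series also depends on the far end of the 4-methoxyphenyl group. The (4-hydroxyphenyl)amino group also separates compound 4 from the two other analogues, with an at least 9.3-fold higher number from compound 2 to compound 4 (0.96 log units; beyond the scatter) and an at least 150-fold higher number from compound 1 to compound 4 (2.19 log units; beyond the scatter), so a group that stood within the scatter of diethylamino as (4-methoxyphenyl)amino no longer does so once its methyl is gone.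

Going by these compounds, the true size of these steps stays open. The result shows only that the loss of the methyl coincides with the loss of measurable activity. Also open, on these data alone, is whether an ethoxy group, a fluorine or an amine at this place would behave like methoxy or like hydroxy, and whether the same change would cost as much in a compound that keeps the butyl chain's simple amine partner.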